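Allyloxy in Place of Allyl on Compound 2

A few compounds are considered here, and "the series" means these few. Any claim that something is new, unique, unknown or untested is made for them only; others in the source may bear on it.

In a functional assay on T98G cells (Homo sapiens) for inhibition, read by colorimetric assay and MTT assay, with a stated time of 72 h (on this read-out higher numbers stand for weaker inhibition and lower numbers for stronger inhibition), compound 1 (`COc1ccc(C)cc1-c1cnc(OCCCCc2ccccc2)n1C`) gives 44000 nM and compound 3 (`C=CCCCCOc1ncc(-c2cccc(OC)c2OC)n1C`) gives 35000 nM as two high numbers. Compound 2 (`C=CCCCCOc1ccccc1-c1cnc(OCCCC=C)n1C`) at 3000 nM has the lowest number of the three, which means the strongest inhibition, and its gap to each of the others lies beyond the scatter of repeated measurements.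

Compound 4 (`C=CCCCCOc1ccccc1-c1cnc(OCCOCC=C)n1C`) has not yet been measured. It differs from compound 2 by one change (allyloxy in place of allyl on a saturated chain carbon, two bonds along the chain from an oxygen on an aromatic ring) with allyloxy in place of allyl on a saturated chain carbon, two bonds along the chain from an oxygen on an aromatic ring.

For the measured compounds named here, no measured pair in this small set isolates a change of this kind, so there is no direct precedent. Compound 2 at 3000 nM is the only starting point, and a small loss seems more likely than a gain. The expected step is a 2.0-fold higher number from compound 2 to compound 4 (0.30 log units; within the scatter) towards weaker inhibition, near the edge of the scatter. In this assay the estimated value for compound 4 is 6000 nM with an expected range from 2000 nM to 20000 nM for the coming measurement.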

Compound 4, half-maximal inhibitory concentration: 65000 nM
Compound 4: middle estimate off by 11-fold (1.03 log units), on the low side; measured number outside the range, above it.
By their numbers in this assay, from the lowest: compound 2; then compounds 3, 1 and 4 (each within the scatter of the next).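

In this assay, putting allyloxy in place of allyl on a saturated chain carbon, two bonds along the chain from an oxygen on an aromatic ring, gives a 22-fold higher number from compound 2 to compound 4 (1.34 log units; beyond the scatter), a large step towards weaker inhibition. For the compounds shown here, this is the first pair here that differs in only one place, and it shows that inhibition at this position is sensitive to a small edit: one extra heavy atom, an oxygen, goes with a large loss. Nothing available here explains why the step is so large.

The change adds an atom and an oxygen at once, so the size of the chain and the presence of the oxygen remain untangled. A longer all-carbon chain, or an amine in place of the oxygen, would help to separate the two.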